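The source may hold more compounds than are shown below. What is called first, only, known or untested is meant among the compounds shown, and "the series" means these compounds.

Working notes on the series. Compound 1 `CS/C(=N\C(=O)c1ccno1)NC(=O)c1ccno1` and compound 2 `CS/C(=N\C(=O)c1ccco1)NC(=O)c1ccco1` share a methylsulfanyl group on the central carbon and differ in the ring borne by the two acyl arms; the difference between the two cores is not broken down here. In a functional assay on K562 cells (Homo sapiens) for cytotoxicity, read by MTT assay, with a stated time of 72 h (on this read-out higher numbers stand for weaker inhibition of growth and lower numbers for stronger inhibition of growth), compound 1 gives only a limit, > 100000 nM. Compound 2 likewise gives only a limit in this assay, > 100000 nM. Compound 3 `O=C(/N=C(/NC(=O)c1ccno1)[Se]Cc1ccccc1)c1ccno1` carries the change a group of 8 heavy atoms (7 carbon, 1 selenium; one six-membered aromatic ring of carbon only) in place of a group of 2 heavy atoms (1 carbon, 1 sulfur; no ring), on a carbon with a double bond to nitrogen and in this assay compound 3 gives 57300 nM. The step is an at least 1.7-fold lower number from compound 1 to compound 3 (0.24 log units; that floor lies within the scatter); it has only a floor because of the limit of > 100000 nM in this assay, at which 2 of the 3 values shown sit.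

Compound 4 `O=C(/N=C(/NC(=O)c1ccco1)[Se]Cc1ccccc1)c1ccco1` is not yet measured. It carries the same change from compound 2, (a group of 8 heavy atoms (7 carbon, 1 selenium; one six-membered aromatic ring of carbon only) in place of a group of 2 heavy atoms (1 carbon, 1 sulfur; no ring), on a carbon with a double bond to nitrogen), at a place described in the same words, so the change is of the same kind. For compound 4 in this assay a step of about an at least 1.5-fold lower number from compound 2 to compound 4 (0.18 log units; that floor lies within the scatter) is expected, resting on the measured step from compound 1 to compound 3 and on the limit of compound 2. The expected value for compound 4 is 65000 nM, estimated to lie between 30000 nM and 150000 nM.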

Compound 4, concentration for total growth inhibition: 44200 nM
Beside the measured number, compound 4's estimate is 1.5-fold (0.17 log units) above it; the measured number falls inside the stated range.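

In this assay, the group of 8 heavy atoms (7 carbon, 1 selenium) in place of methylsulfanyl gives an at least 2.2-fold lower number from compound 2 to compound 4 (0.35 log units; beyond the scatter), a step that is at least modest. On the two cores shown, the change lowers the number in the same direction, so that direction carries over within these two pairs: the same change on two cores in this assay, an at least 1.7-fold lower number (0.24 log units; that floor lies within the scatter) from compound 1 to compound 3 and an at least 2.2-fold lower number (0.35 log units; beyond the scatter) from compound 2 to compound 4; the limit leaves it open whether they differ. Both steps are floors rather than measured sizes, so they do not show that the change has the same size on each core, and two pairs make no general rule: the limit of > 100000 nM in this assay, at which 2 of the 4 values shown sit.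

The entering group differs from methylsulfanyl both in selenium for sulfur and in its six-membered aromatic ring, so the compounds shown leave open which of the two goes with the lower numbers; methylselanyl or benzylsulfanyl on the carbon with a double bond to nitrogen would separate them. Also open, from the compounds shown here alone, is how an amine or a longer chain at that place would read in this assay.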